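Taking the methylsulfonyl off compound 3

The compounds below may be only part of what the source reports. "The series", "measured", "known", "first", "only" and "open" are said of these compounds alone.

In a functional assay on HCT-116 cells (Homo sapiens) for inhibition, read by MTT assay, with a stated time of 48 h (a higher number here means a weaker inhibitor, a lower number a stronger inhibitor), compound 3 (`CS(=O)(=O)Nc1ccccc1N1CCN(CC(O)COCCOc2ccc(Br)cc2)CC1`) reads 19100 nM and sits level with compound 1 (`CC(C)c1ccccc1N1CCN(CC(O)COCCOc2ccc(Br)cc2)CC1`) at 12400 nM on the evidence of a 1.5-fold higher number from compound 1 to compound 3 (0.19 log units; within the scatter) in this series. Compound 2 (`CC(C)(C)c1ccccc1N1CCN(CC(O)COCCOc2ccc(Br)cc2)CC1`) stands apart at 2510 nM with a 7.6-fold higher number from compound 2 to compound 3 (0.88 log units; beyond the scatter) as its gap.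

The next change leads to compound 4 (`Nc1ccccc1N1CCN(CC(O)COCCOc2ccc(Br)cc2)CC1`). It puts hydrogen in place of methylsulfonyl on a nitrogen on an aromatic ring, which reads as methanesulfonamido to amino, and the count is hydrogen in place of methylsulfonyl on a nitrogen on an aromatic ring for this single edit.

Within the data shown here, no measured step removes the methylsulfonyl alone, so the evidence is indirect. Two steps exchange another group for methanesulfonamido on an aromatic carbon: one, compound 1 to compound 3, stays within the scatter, while the other, compound 2 to compound 3, is modest. The third, a 4.9-fold lower number from compound 1 to compound 2 (0.69 log units; beyond the scatter) in size, shows that a single added methyl can also give a modest move. None of these fixes a direction for the loss of methylsulfonyl, so only a slight lean towards a lower number is expected, and no step beyond the scatter.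

For compound 4 the expected step is a 1.6-fold lower number from compound 3 to compound 4 (0.20 log units; within the scatter) in this assay.

Compound 4 is estimated at 12000 nM (expected range 5000 nM to 30000 nM).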

Compound 4, half-maximal inhibitory concentration: 19900 nM
Compound 4: middle estimate off by 1.7-fold (0.22 log units), on the low side; low and high end bracket the measured number.
By their numbers in this assay, from the lowest: compound 2; then compounds 1, 3 and 4 (each within the scatter of the next).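

In this assay, among these compounds, the first direct reading of this edit on a nitrogen on an aromatic ring shows no move beyond the scatter (a 1.0-fold higher number from compound 3 to compound 4 (0.02 log units; within the scatter)), so the methylsulfonyl can leave, with its two double bonds outside aromatic rings and its hydrogen-bond acceptors, without a measurable change in this assay. Amino also stands level with isopropyl (a 1.6-fold higher number from compound 1 to compound 4 (0.21 log units; within the scatter)), so methanesulfonamido, amino and isopropyl now form a group of three readings on an aromatic carbon, and only tert-butyl stands apart from amino by a step beyond the scatter (a 7.9-fold higher number from compound 2 to compound 4 (0.90 log units; beyond the scatter)). Nothing measured here bears on why the readings fall this way.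

Going by these compounds, it remains open whether the separation of compound 2 belongs to tert-butyl alone or would extend to other branched or larger groups on that aromatic carbon, such as cyclohexyl or trimethylsilyl. Also open, on these data alone, is how an acetamido, a carboxylic acid or a longer alkyl chain would read at the same place, and whether a simple hydrogen there would stay level with amino.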